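Phenoxy formamidine analogue: expected partition coefficient

The compounds below may be only part of what the source reports. "The series", "measured", "known", "first", "only" and "open" are said of these compounds alone.

Measured so far:
compound 1 `C#CCOc1c(Cl)cc(N/C=N/OCC)cc1Cl` – 3.6
compound 2 `C#CCc1c(Cl)cc(N/C=N/OC(C)CC)cc1Cl` – 4.2

For the measured compounds named here, in a physicochemical assay for lipophilicity, measured as octanol-water partition (a higher number here means a more lipophilic compound, a lower number a more polar compound), compound 2 gives 4.2, the higher of the two numbers known. Its nearest neighbour is compound 1 with 3.6, lower by a margin beyond the usual scatter; the two compounds differ in more than one place, so the gap is not traced to a single change.

Compound 3 `C#CCc1c(Cl)cc(N/C=N/Oc2ccccc2)cc1Cl` is the next unmeasured member. It differs from compound 2 in one place: phenyl in place of sec-butyl on an oxygen. Going by the values given here, no measured pair isolates this change, so the expectation rests on compound 2 alone. A step of this kind is expected to be small, at most a slight rise, with no clear move beyond the scatter. Compound 3 is therefore expected near 4.3, with a range from 3.8 to 4.8, which implies a step of a number 0.10 log units higher from compound 2 to compound 3 (within the scatter).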

Compound 3, partition coefficient: 4.4
Estimate against measurement, compound 3: 0.10 log units below, and the stated range covers the measured number.
By their numbers in this assay, from the lowest: compound 1; then compounds 2 and 3 (each within the scatter of the next).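

In this assay, for the compounds shown here, the first single-place change is phenyl in place of sec-butyl on the oxygen whose other neighbour is the double-bonded nitrogen, and it gives a number 0.20 log units higher from compound 2 to compound 3 (within the scatter). At this position, then, an open-chain group and a six-membered aromatic ring of carbon only, with a different heavy-atom count, are not separated by this read-out, so the pair gives no handle on the partition coefficient. Nothing at hand accounts for this result.

On these data alone, whether an amine, a carboxylic acid or a longer chain on the same oxygen would also stay within the scatter of compound 2 remains open. Compound 1 differs from compound 2 in more than one place, so the contribution of each difference between them also remains unresolved.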